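From Fluoro to Furan-2-yl on the Shared Core

The compounds below may be only part of what the source reports. "The series", "measured", "known", "first", "only" and "open" are said of these compounds alone.

Measured in a functional assay on CCRF-CEM cells (Homo sapiens) for antiproliferative activity, read by cell counting, with a stated time of 72 h (a lower number here means a stronger inhibitor, a higher number a weaker inhibitor), so far:
Compound 1 `C#C[C@@]1(O)[C@@H](CO)O[C@@H](n2cnc3c(-c4ccc(OC)cc4)ncnc32)[C@@H]1O` gives > 250000 nM (a limit of the assay)
Compound 2 `C#C[C@@]1(O)[C@@H](CO)O[C@@H](n2cnc3c(-c4ccc(Cl)cc4)ncnc32)[C@@H]1O` gives 124000 nM
Compound 3 `C#C[C@@]1(O)[C@@H](CO)O[C@@H](n2cc(F)c3c(N)ncnc32)[C@@H]1O` gives 160 nM

Compound 3 holds the lower of the two actual numbers, and its gap to compound 2 lies far beyond the scatter. Compound 1 gives only a limit (> 250000 nM) and no number.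

Compound 4 `C#C[C@@]1(O)[C@@H](CO)O[C@@H](n2cc(-c3ccco3)c3c(N)ncnc32)[C@@H]1O` has not yet been measured. It differs from compound 3 by furan-2-yl in place of fluoro on an aromatic carbon and is otherwise unchanged. Within the data shown here, the one measured step (an at least 2.0-fold lower number from compound 1 to compound 2 (0.30 log units; that floor lies within the scatter)) swaps other groups at another place, so it gives no direct size for this change. Compound 2, which carries an aromatic group on its core, gives 124000 nM in that same read-out, and this is only a loose hint. A higher number is therefore expected in this assay with an estimated step (a 19-fold higher number from compound 3 to compound 4 (1.27 log units; beyond the scatter)) beyond the scatter. For compound 4 the estimate is 3000 nM within an expected range from 300 nM to 40000 nM in this read-out.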

Compound 4, half-maximal inhibitory concentration: 17000 nM
Compound 4: the middle estimate sits 5.7-fold (0.75 log units) below what was measured; low and high end bracket the measured number.
By their numbers in this assay, from the lowest: compound 3; then compound 4; then compound 2. At a limit, above all of these: compound 1.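

In this assay, furan-2-yl in place of fluoro gives a 110-fold higher number from compound 3 to compound 4 (2.03 log units; beyond the scatter), the only measured size of a change at this aromatic carbon, two ring bonds from the ring nitrogen. The swap brings in a five-membered aromatic ring and one hydrogen-bond acceptor, and the read-out still gives an actual number rather than a limit. This step has actual numbers at both ends, whereas compound 1 gives only a limit: the limit of > 250000 nM in this assay, at which 1 of the 4 values shown sits.

Only fluoro and furan-2-yl are shown at this position, so the step does not tell whether the ring itself, its oxygen or simply the larger group goes with the higher number. As far as these compounds go, how a methyl group, a nitrile, an amine or a phenyl ring would read at this carbon remains open.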